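The source may hold more compounds than are shown below. What is called first, only, known or untested is meant among the compounds shown, and "the series" means these compounds.

Measured so far:
compound 1, `O=C1OC(c2ccc(Cl)cc2)=C/C1=C\c1ccc(F)cc1`, 41.3%
compound 2, `COc1ccc(/C=C2\C=C(c3ccc(Cl)cc3)OC2=O)cc1`, 4%

In a functional assay on the whole organism (strain Wistar) for inhibition, with Rattus norvegicus as the target, with stated times of 30 min and 2 h, at a dose of 20 mg/kg by the oral route (on this read-out lower numbers stand for less inhibition and higher numbers for more inhibition at the one dose given (going by the name of the read-out)), compound 1 gives 41.3%, while compound 2 gives 4%, the lower of the two numbers. Going by the values given here, the single measured step, a number 37.3 percentage points lower from compound 1 to compound 2 (beyond the scatter), came with methoxy in place of fluoro on an aromatic carbon. Compound 3, `COc1ccc(/C=C2\C=C(c3ccc(Cl)cc3)OC2=O)cc1OC`, differs from compound 2 by methoxy in place of hydrogen on an aromatic carbon, placed ortho to a methoxy group. Among the compounds with values here, no measured step adds a second methoxy to the same ring, so the one recorded step bears on it only loosely: it shows that a change on this ring can move the read-out a great deal, but it swapped one group for another rather than adding one. Compound 2 already sits near the bottom of the scale, which leaves little room for a further fall. The expected step is a number 4 percentage points higher from compound 2 to compound 3 (within the scatter), which would not clearly exceed the scatter. For compound 3 the estimate in this assay is 8%, with a range from 0% to 25%.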

Compound 3, a percentage reported as inhibition, in the whole organism at one dose (the size of the read-out at that dose, not a potency): 9.33%
Compound 3: middle estimate off by 1.3 percentage points, on the low side; the measured number falls inside the stated range.
By their numbers in this assay, from the lowest: compounds 2 and 3 (each within the scatter of the next); then compound 1.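

In this assay, methoxy in place of hydrogen on an aromatic carbon, ortho to a methoxy group, gave a number 5.3 percentage points higher from compound 2 to compound 3 (within the scatter) and so leaves compound 3 and compound 2 indistinguishable on this read-out. The earlier step swapped one group for another on this ring, whereas this step adds a group to a ring that already carries methoxy, and that second methoxy does not separate the two compounds beyond the scatter. No measured evidence here offers an explanation for this result.

On these data alone, it remains open whether a hydroxyl, an amine or a carboxylic acid at this same position would give a number clearly different from that of compound 2. As far as these compounds go, it is also open whether adding methoxy at a comparable place on the fluoro-bearing ring of compound 1 would leave its number unchanged.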